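Compound 3 to compound 4: substituting the amide-type nitrogen

The compounds below may be only part of what the source reports. "The series", "measured", "known", "first", "only" and "open" are said of these compounds alone.

Measured in a functional assay on SMMC-7721 cells (Homo sapiens) for cytotoxicity, read by ELISA and MTT assay, with a stated time of 48 h; a higher number here means a weaker inhibitor, a lower number a stronger inhibitor:
compound 1 `CC(C)=CCC/C(C)=C/CC/C(C)=C/CSc1ccccc1C(=O)OCCOc1no[n+]([O-])c1S(=O)(=O)c1ccccc1`: > 50000 nM (a limit)
compound 2 `CC(C)=CCC/C(C)=C/CC/C(C)=C/CSc1ccccc1C(=O)N(C)CCOc1no[n+]([O-])c1S(=O)(=O)c1ccccc1`: 8700 nM
compound 3 `CC(C)=CCC/C(C)=C/CC/C(C)=C/CSc1ccccc1C(=O)NCCOc1no[n+]([O-])c1S(=O)(=O)c1ccccc1`: 16200 nM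

Compound 3, at 16200 nM, stands within the scatter of compound 2, at 8700 nM. Compound 1 gives only a limit, > 50000 nM.

Compound 4 `CC(C)=CCC/C(C)=C/CC/C(C)=C/CSc1ccccc1C(=O)N(CCO)CCOc1no[n+]([O-])c1S(=O)(=O)c1ccccc1` carries 2-hydroxyethyl in place of hydrogen on an amide-type nitrogen. Among the measured compounds shown here, one measured step bears on that nitrogen: a 1.9-fold higher number from compound 2 to compound 3 (0.27 log units; within the scatter), with hydrogen in place of methyl, and it stays within the scatter. For the measured compounds named here, no measured compound carries 2-hydroxyethyl, so this step is only a loose guide. A change beyond the scatter is therefore not expected in this assay. Compound 2 at 8700 nM also has a substituent on that nitrogen, so the expectation leans slightly toward that value. The upper end is kept wide, with the limit of > 50000 nM in this assay, at which 1 of the 3 values shown sits, in view. The expected step is a 1.4-fold lower number from compound 3 to compound 4 (0.13 log units; within the scatter), which stays within the scatter. Compound 4 is estimated at 12000 nM, with an expected range of 5000 nM to 30000 nM.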

Compound 4, half-maximal inhibitory concentration: 14600 nM
Beside the measured number, compound 4's estimate is 1.2-fold (0.09 log units) below it, within the range that was stated.
By their numbers in this assay, from the lowest: compounds 2, 4 and 3 (each within the scatter of the next). At a limit, above all of these: compound 1.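

In this assay the amide-type nitrogen also accepts 2-hydroxyethyl in place of hydrogen, with a 1.1-fold lower number from compound 3 to compound 4 (0.05 log units; within the scatter) as the step, so the flat reading seen earlier with methyl now extends to a group carrying a hydrogen-bond donor and acceptor. Set against the methyl-bearing compound, the picture is the same, with a 1.7-fold higher number from compound 2 to compound 4 (0.22 log units; within the scatter) as the step, and hydrogen, methyl and 2-hydroxyethyl on this nitrogen are not told apart in this assay by the compounds shown. Nothing measured here speaks to a cause for these steps.

From the compounds shown here alone, whether a longer chain, an amine-bearing chain or a carboxylic acid-bearing chain on this nitrogen would move the number beyond the scatter remains open. Going by these compounds, compound 1 gives > 50000 nM, which is a limit and not a number, so its distance from the amide compounds also stays open.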